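Methyl for pyridin-2-yl on the piperazine of compound 1

This account rests on a few compounds, and the source may have more. Where it says the series, first, only, none or still open, it means among the compounds named here.

Compound 1 `COc1ccc(C[C@@H](O)/C=C/C=C/C(=O)N2CCN(c3ccccn3)CC2)cc1OC`: 11100 nM
Compound 2 `COc1ccc(C[C@@H](O)/C=C/C=C/C(=O)N2CCN(c3ccccc3)CC2)cc1OC`: 9430 nM
Compound 3 `COc1ccc(C[C@@H](O)/C=C/C=C/C(=O)N2CCN(c3ncccn3)CC2)cc1OC`: 10800 nM

In a functional assay on IMR-32 cells (Homo sapiens) for antiproliferative activity, read by sulforhodamine B assay, with a stated time of 48 h (a higher number here means a weaker inhibitor, a lower number a stronger inhibitor), compound 1 gives the highest of the three numbers, but its nearest neighbour compound 3 sits within the scatter, and so does compound 2. The measured steps, a 1.2-fold lower number from compound 1 to compound 2 (0.07 log units; within the scatter), a 1.0-fold lower number from compound 1 to compound 3 (0.01 log units; within the scatter) and a 1.1-fold higher number from compound 2 to compound 3 (0.06 log units; within the scatter), all lie within the scatter, so exchanging one aromatic ring on the ring nitrogen for another left the read-out unchanged. Compound 4 `COc1ccc(C[C@@H](O)/C=C/C=C/C(=O)N2CCN(C)CC2)cc1OC` differs from compound 1 by methyl in place of pyridin-2-yl on an amine nitrogen in a ring. Among the compounds with values here, no measured step removes the aromatic ring altogether, so the aryl swaps bear on this change only loosely. For compound 4 a step no larger than the scatter is expected, a 1.3-fold higher number from compound 1 to compound 4 (0.10 log units; within the scatter), and its estimated value is 14000 nM with a range from 5000 nM to 45000 nM.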

Compound 4, half-maximal inhibitory concentration: 18900 nM
Compound 4: the middle estimate sits 1.4-fold (0.13 log units) below what was measured; low and high end bracket the measured number.
By their numbers in this assay, from the lowest: compounds 2, 3, 1 and 4 (each within the scatter of the next).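

In this assay, replacing the aromatic ring on the amine nitrogen with a single methyl still gives steps within the scatter (a 1.7-fold higher number from compound 1 to compound 4 (0.23 log units; within the scatter); a 1.8-fold higher number from compound 3 to compound 4 (0.24 log units; within the scatter); a 2.0-fold higher number from compound 2 to compound 4 (0.30 log units; within the scatter)). Among these four compounds, then, the read-out shows no need for an aromatic ring at this position, whether pyridin-2-yl, pyrimidin-2-yl or phenyl. Nothing measured here offers an explanation for this. Still open, as far as these compounds go, is whether a benzyl group, a longer chain such as butyl, or a carboxylic acid on that nitrogen would move the number beyond the scatter.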